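This account rests on a few compounds, and the source may have more. Where it says the series, first, only, none or still open, it means among the compounds named here.

For the measured compounds named here, compound 2 `O=S(=O)(NCCN1CCC(CNC2CCCc3ccccc3C2)CC1)c1cccc2ccccc12` gives the only number among the values shown: in an assay on isolated protein for inhibition of Neuropeptide Y receptor type 5 (Homo sapiens) (on this read-out lower numbers stand for stronger inhibition and higher numbers for weaker inhibition), compound 2 gives 210 nM. Compound 1 `COc1cccc2c1CCCC(NCCN1CCC(CNS(=O)(=O)c3cccc4ccccc34)CC1)C2` sits at a limit of this assay rather than a number, > 1000 nM in this assay, which is the limit of > 1000 nM in this assay, at which 1 of the 2 values shown sits. Compound 3 `Cc1ccc2c(c1)CC(NCC1CCN(CCNS(=O)(=O)c3cccc4ccccc34)CC1)CCC2` differs from compound 2 by methyl in place of hydrogen on an aromatic carbon. Going by the values given here, no step between measured compounds is available for this change. In this assay the step from compound 2 to compound 3 is expected to be small, toward weaker inhibition or none beyond the scatter, a 1.4-fold higher number from compound 2 to compound 3 (0.15 log units; within the scatter). Compound 3 is therefore estimated at 300 nM, between 100 nM and 1000 nM.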

Compound 3, half-maximal inhibitory concentration: 72 nM
Estimate against measurement, compound 3: 4.2-fold (0.62 log units) above; measured number below the stated range.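

On this aromatic carbon, meta to a fused ring and para to a fused ring, methyl in place of hydrogen strengthens inhibition in this assay, with a 2.9-fold lower number from compound 2 to compound 3 (0.46 log units; beyond the scatter) on this single change. It is the first step shown at this position, and it lies beyond the scatter, so this carbon carries a methyl without loss. Compound 1, with a methoxy group on the core, stands at a limit of the assay and not at a number: the limit of > 1000 nM in this assay, at which 1 of the 3 values shown sits. As far as these compounds go, whether ethyl, chlorine or methoxy at this same carbon would go further remains open. So does whether methyl on the other aromatic carbons of this ring would give a similar step.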